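The source may hold more compounds than are shown below. What is called first, only, known or untested is meant among the compounds shown, and "the series" means these compounds.

Measured in an ADME assay on MT4 cells (Homo sapiens) for cytotoxicity, read by MTT assay; on this read-out higher numbers stand for lower toxicity in this test and lower numbers for higher toxicity in this test:
- compound 1 `O=C(CSc1nc(Cc2c(Cl)cccc2Cl)cc(=O)[nH]1)c1ccc(F)cc1`: > 59000 nM
- compound 2 `CCc1c(Cc2c(Cl)cccc2Cl)nc(SCC(=O)c2ccc(F)cc2)[nH]c1=O`: > 55000 nM
- compound 3 `CC(C)c1c(Cc2c(Cl)cccc2Cl)nc(SCC(=O)c2ccccc2)[nH]c1=O`: > 56000 nM

All three entries are limits, not exact numbers. Compound 3 therefore has no exact position, and its result is only the limit > 56000 nM.

The next compound, compound 4 `CC(C)c1c(Cc2c(Cl)cccc2Cl)nc(SCC(=O)c2ccc(F)cc2)[nH]c1=O`, differs from it by one small change: fluoro in place of hydrogen on an aromatic carbon. In words, this is fluoro in place of hydrogen on an aromatic carbon, turning the phenyl into 4-fluorophenyl.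

Among the measured compounds shown here, the only measured step between two compounds that differ in one place is a step that the two limits leave unreadable from compound 1 to compound 2. It concerns ethyl rather than fluoro, and it gives no size to carry over. Compound 2 already has the 4-fluorophenyl group, and its result is also only a limit, > 55000 nM.

With no measured size to draw on, the expected change is none beyond the scatter, and the estimate is an at least 1.0-fold lower number from compound 3 to compound 4 (0.01 log units; that floor lies within the scatter). Compound 4 will probably be reported as a limit too.

For compound 4, the estimated value is 54000 nM, with an expected range from 25000 nM to 60000 nM.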

Compound 4, half-maximal cytotoxic concentration: > 54000 nM
Compound 4: a limit, no number (the forecaster's own chance of this, stated with the estimate: 85%); the middle value lies on the limit itself.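

In this assay, among the compounds shown here, compound 4 gives only a limit, as do compound 1, compound 2 and compound 3, so no step between these compounds can be read. The compounds shown leave open how large any of these changes is, and at what concentration any of the four becomes toxic to the cells.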